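A few compounds are considered here, and "the series" means these few. Any claim that something is new, unique, unknown or untested is made for them only; others in the source may bear on it.

Measured so far in this series:
compound 1 `CC(C)[C@@H]1CC[C@@H](C)C[C@@]12N(C)C(=O)[C@@H]1[C@H]3C(=O)NC(=O)[C@H]3ON12` — 35.6%
compound 2 `CC(C)[C@@H]1CC[C@@H](C)C[C@@]12N(C)C(=O)[C@@H]1[C@H]3C(=O)N(c4ccccc4)C(=O)[C@H]3ON12` — 35.4%
compound 3 `CC(C)[C@@H]1CC[C@@H](C)C[C@@]12N(C)C(=O)[C@@H]1[C@H]3C(=O)N(c4ccc(Cl)cc4)C(=O)[C@H]3ON12` — 53.7%

All numbers come from a functional assay, read by spectrophotometry, with a stated time of 2 h, tested at 1 mg/mL; on this read-out higher numbers stand for a stronger effect at the one concentration tested and lower numbers for a weaker effect. Compound 1 stands second highest of the three: compound 2 sits within the scatter of it, and compound 3 is the only one separated from it beyond the scatter.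

Compound 4 `CC(C)[C@@H]1CC[C@@H](C)C[C@@]12N(C)C(=O)[C@@H]1[C@H]3C(=O)N(c4ccc5ccccc5c4)C(=O)[C@H]3ON12` differs from compound 1 in one place: naphthalen-2-yl in place of hydrogen on an amide-type nitrogen in a ring. Among the compounds with values here, three measured steps bear on this change, all at the same nitrogen. A bare phenyl gave a number 0.2 percentage points lower from compound 1 to compound 2 (within the scatter), so the first aryl substituent alone left the read-out unchanged. A 4-chlorophenyl gave a number 18.1 percentage points higher from compound 1 to compound 3 (beyond the scatter), and the chloro alone accounts for it, since a number 18.3 percentage points higher from compound 2 to compound 3 (beyond the scatter). Naphthalen-2-yl is a second carbon ring fused onto the aryl rather than a chloro, and no measured compound carries such a group, so the step is not read off directly. The phenyl result argues for no change, the 4-chlorophenyl result for a modest rise; the estimate is set between them, leaning toward the larger group. Compound 4 is therefore expected to give 44%, with a range from 30% to 60%. The expected step is a number 8.4 percentage points higher from compound 1 to compound 4 (within the scatter), small and uncertain in direction.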

Compound 4, a percentage reported as activity, at one concentration (the size of the read-out at that concentration, not a potency): 29.6%
Estimate against measurement, compound 4: 14.4 percentage points above; measured number below the stated range.
By their numbers in this assay, from the lowest: compounds 4, 2 and 1 (each within the scatter of the next); then compound 3.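

In this assay naphthalen-2-yl on the amide-type nitrogen in the ring gives no separation from the hydrogen of compound 1 (a number 6 percentage points lower from compound 1 to compound 4 (within the scatter)) or from the phenyl of compound 2 (a number 5.8 percentage points lower from compound 2 to compound 4 (within the scatter)), so a second aromatic ring fused onto the aryl does not reproduce what the 4-chlorophenyl gives at this nitrogen. Exchanging that 4-chlorophenyl for naphthalen-2-yl gives a step beyond the scatter (a number 24.1 percentage points lower from compound 3 to compound 4 (beyond the scatter)), which leaves compound 3 as the only one of the four apart from the rest, with hydrogen, phenyl and naphthalen-2-yl forming a single group within the scatter. No measured evidence is at hand on what separates the 4-chlorophenyl from the other groups at this position.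

From the compounds shown here alone, it remains open whether the higher number belongs to chloro in particular, or whether a 4-fluorophenyl, 4-bromophenyl or 4-methoxyphenyl on this nitrogen would behave as the 4-chlorophenyl does. Going by these compounds, it is also open what a non-aromatic group here, such as a benzyl or a longer alkyl chain, would give on the shared core.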